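Removing one fluoro from a benzyl group in a cell assay

The compounds below may be only part of what the source reports. "The series", "measured", "known", "first", "only" and "open" are said of these compounds alone.

Compound 3, with the structure `CCOC(=O)CN(Cc1cc(F)cc(F)c1)c1ccc2c(c1)N(C)CC(C)(COc1ccc(C(=N)N)cc1)O2`, is followed here through a change in one of its aromatic rings. In a functional assay on MCF7 cells (Homo sapiens) for antiproliferative activity, read by cell counting, with a stated time of 4 days (a lower number here means a stronger inhibitor, a higher number a weaker inhibitor), compound 3 gives 4500 nM, the lowest of the two numbers shown. The related compound 1, with the structure `CCOC(=O)CN(Cc1cc(F)cc(F)c1)c1ccc2c(c1)OC(C)(COc1ccc(C#N)cc1)CN2C`, gives 54000 nM in this assay, a higher number that lies beyond the usual scatter. Compound 2, with the structure `CCOC(=O)C(=O)N(Cc1ccccc1)c1ccc2c(c1)OC(C)(CO)CN2C`, reaches only a limit of this assay: it gives > 100000 nM, which is the limit of > 100000 nM in this assay, at which 1 of the 3 values shown sits, not a measured number.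

The new compound 4, with the structure `CCOC(=O)CN(Cc1cccc(F)c1)c1ccc2c(c1)N(C)CC(C)(COc1ccc(C(=N)N)cc1)O2`, differs from compound 3 by hydrogen in place of fluoro on an aromatic carbon. Since the rest of the molecule stays the same, the step is expected to be small, a 1.3-fold higher number from compound 3 to compound 4 (0.12 log units; within the scatter), and not beyond the scatter. Compound 4 is therefore estimated at 6000 nM in this assay, within a range from 2500 nM to 15000 nM.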

Compound 4, half-maximal inhibitory concentration: 4200 nM
For compound 4 the middle estimate is 1.4-fold (0.15 log units) above the measured one; measured number inside the range.
By their numbers in this assay, from the lowest: compounds 4 and 3 (each within the scatter of the next); then compound 1. At a limit, above all of these: compound 2.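

Compounds 3 and 4 are the first pair shown that differ in one place only, so the weight of a single fluoro on this aromatic ring can now be read directly. In this assay, going from the 3,5-difluorobenzyl group to the 3-fluorobenzyl group gives a 1.1-fold lower number from compound 3 to compound 4 (0.03 log units; within the scatter), so the two compounds cannot be told apart here, and the second fluoro is not needed to hold this level of antiproliferative activity. Nothing measured here speaks to why the number holds.

Whether the remaining fluoro matters on this core stays open, since an unsubstituted benzyl group with everything else kept is not among the compounds shown. Going by these compounds, it is equally open how a larger group at this place, such as a chloro or a methoxy group, would read in this assay.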